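A few compounds are considered here, and "the series" means these few. Any claim that something is new, unique, unknown or untested is made for them only; others in the source may bear on it.

Compound 2, with the structure `CC(C)N(Cc1cccc(OCCCCCC(=O)O)c1)C(=O)c1ccc(-c2cccc(O)c2)cc1`, is the starting point of this step. In an ADME assay on HEK293 cells (Homo sapiens) for cytotoxicity, read by CellTiter-Glo and resazurin assay, with a stated time of 72 h (on this read-out lower numbers stand for an effect already at smaller amounts and higher numbers for an effect only at larger amounts of compound), compound 2 gives > 26000 nM, which is a limit of the assay rather than a measured number. Among the compounds with values here, its only measured neighbour is compound 1, `CC(C)Oc1cccc(-c2ccc(C(=O)N(Cc3cccc(OCCCCCC(=O)O)c3)C(C)C)cc2)c1`, which differs from it by a hydrogen in place of an isopropyl on an oxygen on an aromatic ring. In this assay compound 1 likewise gives > 26000 nM, again a limit and not a number. The step that the two limits leave unreadable from compound 1 to compound 2 is therefore not readable in size or direction, and the one observation that can be drawn from the pair is the limit of > 26000 nM in this assay, at which 2 of the 2 values shown sit.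

Compound 3, `CC(C)N(Cc1cccc(OCCCCCC(=O)O)c1)C(=O)c1ccc(-c2cccc(OC(F)(F)F)c2)cc1`, has not yet been measured. It differs from compound 2 by trifluoromethyl in place of hydrogen on an oxygen on an aromatic ring. Within the data shown here, no measured step in the set bears on this change with a readable size, so nothing in the data points to a departure from the limit in either direction. The expectation for compound 3 in this assay is that it again shows no effect up to the limit, giving an estimated 30000 nM within 13000 nM to 100000 nM. The estimated step that the limit leaves unreadable from compound 2 to compound 3 is accordingly expected to lie within the scatter.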

Compound 3, half-maximal effective concentration: > 26000 nM
Compound 3 was reported as a limit; the forecaster's own chance of this, stated with the estimate: 85%; the middle value lies beyond the limit too.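

In this assay compound 3 gives > 26000 nM, which is a limit of the assay and not a number. Its steps to compound 1 and compound 2 therefore cannot be read, and the set comes down to one observation: the limit of > 26000 nM in this assay, at which 3 of the 3 values shown sit.

The compounds shown leave open whether, and at what concentration, any of the three would have an effect in this assay.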